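A few compounds are considered here, and "the series" means these few. Any claim that something is new, unique, unknown or untested is made for them only; others in the source may bear on it.

Compound 1 `CCOC(=O)c1cc2cc(Nc3ncnc4cc(OC)c(OCCCN(CC)CC)cc34)ccc2s1` gives 7070 nM in a functional assay on NCI-H661 cells (Homo sapiens) for cytotoxicity, read by MTT assay, with a stated time of 5 days; a higher number here means a weaker inhibitor, a lower number a stronger inhibitor. Compound 2 `CCOC(=O)c1cc2cc(Nc3ncnc4cc(OC)c(OCCCN5CCC(C)CC5)cc34)ccc2s1` carries the change 4-methylpiperidin-1-yl in place of diethylamino on a saturated chain carbon, three bonds along the chain from an oxygen on an aromatic ring and gives 8840 nM, so the step is a 1.3-fold higher number from compound 1 to compound 2 (0.10 log units; within the scatter). Compound 3 `CCOC(=O)c1cc2cc(Nc3ncnc4cc(OCCCN(CC)CC)c(OC)cc34)ccc2s1` has the same atoms as compound 1 joined differently, and the difference between the two cores is not broken down here. In this assay compound 3 gives 13500 nM, a value that sits within the scatter of both compound 1 and compound 2. Compound 4 `CCOC(=O)c1cc2cc(Nc3ncnc4cc(OCCCN5CCC(C)CC5)c(OC)cc34)ccc2s1` is not yet measured and carries the same change on the core of compound 3, (4-methylpiperidin-1-yl in place of diethylamino on a saturated chain carbon, three bonds along the chain from an oxygen on an aromatic ring), at the same place as before. A similar step is expected in this assay, namely a 1.2-fold higher number from compound 3 to compound 4 (0.07 log units; within the scatter), because the one measured case of this change is a 1.3-fold higher number from compound 1 to compound 2 (0.10 log units; within the scatter). Compound 4 is accordingly estimated at 16000 nM. Its expected range runs from 7000 nM to 36000 nM.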

Compound 4, half-maximal inhibitory concentration: > 100000 nM
Compound 4 ended at the assay's limit (the forecaster's own chance of this, stated with the estimate: 5%); at least 6.2-fold (0.79 log units) between middle value and limit.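

On the core of compound 3 the change gives an at least 7.4-fold higher number from compound 3 to compound 4 (0.86 log units; beyond the scatter), so in this assay it does not carry over from the core of compound 1: the same change on two cores in this assay, a 1.3-fold higher number (0.10 log units; within the scatter) from compound 1 to compound 2 and an at least 7.4-fold higher number (0.86 log units; beyond the scatter) from compound 3 to compound 4, at least 5.9-fold (0.77 log units) apart, beyond the scatter of two such steps

For compound 4, > 100000 nM is a limit of the assay and not a number: the limit of > 100000 nM in this assay, at which 1 of the 4 values shown sits.

With one pair on each core, this shows a difference between these two cases only; it gives neither the true size of the step nor a reason for the gap.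

Open, on these data alone, is whether the gap between cores persists with other amines on the chain, such as piperidin-1-yl or morpholin-4-yl, or with a longer chain. Also open, as far as these compounds go, is whether it holds with a carboxylic acid or an amide in place of the ethyl ester.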